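This account rests on a few compounds, and the source may have more. Where it says the series, first, only, none or still open, it means among the compounds named here.

Measured so far in a functional assay on blood (Homo sapiens), with a stated time of 60 min, in the presence of a further agent that is not named here; on this read-out lower numbers stand for an effect already at smaller amounts and higher numbers for an effect only at larger amounts of compound:
- compound 1 `COC(=O)C1(S(=O)(=O)c2ccc(Oc3ccc(OC(F)(F)F)cc3)cc2)CCC2(CCNCC2)C1` gives > 15000 nM (a limit)
- compound 2 `O=S(=O)(c1ccc(Oc2ccc(OC(F)(F)F)cc2)cc1)C1(CO)CCC2(CCNCC2)C1` gives > 15000 nM (a limit)
- compound 3 `O=C1CN(C(=O)C2(S(=O)(=O)c3ccc(Oc4ccc(OC(F)(F)F)cc4)cc3)CCC3(CCNCC3)C2)CCN1` gives 7500 nM (a number)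

Going by the values given here, compound 3 holds the only actual number so far (7500 nM). Compound 1 and compound 2 stand at the limit of > 15000 nM in this assay, at which 2 of the 3 values shown sit, and give no number.

Compound 4 `Nc1ccccc1NC(=O)C1(S(=O)(=O)c2ccc(Oc3ccc(OC(F)(F)F)cc3)cc2)CCC2(CCNCC2)C1` is not yet measured. It carries (2-aminophenyl)amino in place of 3-oxopiperazin-1-yl on a carbonyl carbon. The carbonyl carbon itself stays on the saturated ring carbon.

Among the compounds with values here, two measured steps bear on this place: an at least 2.0-fold lower number from compound 1 to compound 3 (0.30 log units; that floor lies within the scatter) and an at least 2.0-fold lower number from compound 2 to compound 3 (0.30 log units; that floor lies within the scatter). Both are floors rather than sizes. The third, a step that the two limits leave unreadable from compound 1 to compound 2, gives no size at all. Within the data shown here, no compound with an aromatic amide has been measured, so the expectation rests on compound 3 (7500 nM) as the starting point.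

No step beyond the scatter is expected in this assay. The estimated change is a 1.3-fold higher number from compound 3 to compound 4 (0.12 log units; within the scatter) and it stays an expectation only. For compound 4 the estimated value is 10000 nM, with an expected range of 3000 nM to 30000 nM, and a reading that is only a limit would fit as well.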

Compound 4, half-maximal effective concentration: 900 nM
For compound 4 the middle estimate is 11-fold (1.05 log units) above the measured one; the whole stated range lies above it.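

In this assay, going by these compounds alone, the carbonyl carbon on the saturated ring carbon turns out to tolerate a change of amide group with an effect beyond the scatter: (2-aminophenyl)amino in place of 3-oxopiperazin-1-yl gives an 8.3-fold lower number from compound 3 to compound 4 (0.92 log units; beyond the scatter), a size that no earlier pair could show. Against the hydroxymethyl and methoxycarbonyl compounds on the same core, the record reads an at least 16-fold lower number from compound 2 to compound 4 (1.22 log units; beyond the scatter) and an at least 16-fold lower number from compound 1 to compound 4 (1.22 log units; beyond the scatter), so compound 4 stands clear of all three earlier compounds. Those two steps are floors and not sizes, and the step between compound 1 and compound 2 cannot be read, because both of those compounds sit at a limit: the limit of > 15000 nM in this assay, at which 2 of the 4 values shown sit.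

The single exchange brings in the aromatic ring and the amino group on it together, so the compounds shown cannot assign the step to either part of (2-aminophenyl)amino. On these data alone, that question stays open until a plain phenylamino group, without the amino group, or a (2-hydroxyphenyl)amino group, with a hydroxyl in its place, can be read at this same carbonyl carbon on the same core.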